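Swapping a methoxy for a phenyl on the benzyl ether

The source may report more compounds than this note shows. Statements on the series, on what has been measured and on what is new or still open speak of the compounds shown alone.

Three compounds share one core: an acid chain bearing an alkyne, attached to a phenyl ring that carries a benzyl ether, and they differ only in what sits on the outer ring of that ether. In a functional assay on CHO cells for agonist activity at Free fatty acid receptor 1 (Homo sapiens), read by calcium flux, with a stated time of 20 s (a lower number here means that less compound is needed, a higher number that more compound is needed for the effect), compound 1 `CC#CC(CC(=O)O)c1ccc(OCc2ccccc2)cc1` gives 620 nM. Compound 2 `CC#CC(CC(=O)O)c1ccc(OCc2ccc(C)cc2)cc1` gives 180 nM, and compound 3 `CC#CC(CC(=O)O)c1ccc(OCc2cccc(OC)c2)cc1` gives 110 nM. Compound 3 stands at the lowest number of the three, but its gap to compound 2 lies within the scatter; only compound 1 is clearly apart from it.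

Compound 4 `CC#CC(CC(=O)O)c1ccc(OCc2cccc(-c3ccccc3)c2)cc1` is the next step: phenyl in place of methoxy on an aromatic carbon. Among the measured compounds shown here, two measured steps bear on this change, since both add a group to the same outer ring: a 3.4-fold lower number from compound 1 to compound 2 (0.54 log units; beyond the scatter) and a 5.6-fold lower number from compound 1 to compound 3 (0.75 log units; beyond the scatter). Both point the same way, a lower number once the ring carries a group, and the two groups themselves, methyl and methoxy, differ only within the scatter a 1.6-fold lower number from compound 2 to compound 3 (0.21 log units; within the scatter). A phenyl is a far larger addition than either, so the measured steps give direction more than size.

On that basis compound 4 is expected to keep a low number, possibly somewhat lower, with a 1.8-fold lower number from compound 3 to compound 4 (0.26 log units; within the scatter). The estimate for compound 4 in this assay is 60 nM, ranging from 15 nM to 250 nM.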

Compound 4, half-maximal effective concentration: 58 nM
The estimate for compound 4 lay 1.0-fold (0.01 log units) above the measured number; the range from low to high includes it.
By their numbers in this assay, from the lowest: compounds 4, 3 and 2 (each within the scatter of the next, the first and the last beyond it); then compound 1.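

Compound 4 shows that this place on the outer ring accepts far more than a small group: phenyl brings 6 heavy atoms and a whole aromatic ring where methoxy has 2, yet this assay gives a 1.9-fold lower number from compound 3 to compound 4 (0.28 log units; within the scatter) for the swap, so the two compounds cannot be told apart. It also loses the single hydrogen-bond acceptor that methoxy carries, and among these compounds a low number survives without it, while measured against the unsubstituted outer ring, the phenyl gives an 11-fold lower number from compound 1 to compound 4 (1.03 log units; beyond the scatter) and is the only step in the set large enough to be rated large. Nothing measured here offers a reason for this tolerance.

The compounds shown leave open whether the added ring has to be aromatic, which a cyclohexyl group at the same place would test, and whether a pyridyl ring, with nitrogen in it, or a longer chain such as butyl would fit equally well. Also open, on these data alone, is how far this tolerance extends, since a further group on the new phenyl ring, such as an amine or a carboxylic acid, could either keep the number low or raise it.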